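Swapping a chain end for a phenyl ring

This account rests on a few compounds, and the source may have more. Where it says the series, first, only, none or still open, it means among the compounds named here.

Of the compounds shown here, three sharing one core have been tested in an assay on membranes from lung (Cavia porcellus) for binding affinity to cysteinyl leukotriene receptor (Homo sapiens); on this read-out lower numbers stand for stronger inhibition and higher numbers for weaker inhibition. Compound 1 `CCCCCCCCCCCOc1ccccc1C(SCCC(=O)O)SCCC(=O)O` gives 287 nM. Compound 3 `CCCCC/C=C/C/C=C/COc1ccccc1C(SCCC(=O)O)SCCC(=O)O` gives 1000 nM. Compound 2 `CCCCCCCCCOc1ccccc1C(SCCC(=O)O)SCCC(=O)O` gives 4090 nM, the weakest of the three, with steps a 4.1-fold lower number from compound 2 to compound 3 (0.61 log units; beyond the scatter) and, in reverse, a 14-fold higher number from compound 1 to compound 2 (1.15 log units; beyond the scatter). Compound 4 `O=C(O)CCSC(SCCC(=O)O)c1ccccc1OCCCCCCc1ccccc1` differs from compound 2 by phenyl in place of propyl on a saturated chain carbon, six bonds along the chain from an oxygen on an aromatic ring, so the chain grows by a ring. Among the compounds with values here, no measured step covers a ring at this place; the steps that do exist show that a longer chain gave a lower number, while the dienyl change gave a modest one. Compound 4 is therefore expected to show a modest drop, a 5.8-fold lower number from compound 2 to compound 4 (0.77 log units; beyond the scatter), to an estimated 700 nM, between 150 nM and 3000 nM.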

Compound 4, inhibition constant: 11500 nM
Compound 4: the middle estimate sits 16-fold (1.22 log units) below what was measured, and the stated range ends below it.
By their numbers in this assay, from the lowest: compound 1; then compound 3; then compound 2; then compound 4.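

Here a ring at the chain end does not act like added chain length: phenyl in place of propyl, six bonds along the chain from an oxygen on an aromatic ring, raises the number (a 2.8-fold higher number from compound 2 to compound 4 (0.45 log units; beyond the scatter)), whereas the longer saturated chain had gone with a lower one. Phenyl in place of pentyl at that place gives the largest step in the set (a 40-fold higher number from compound 1 to compound 4 (1.60 log units; beyond the scatter)). Nothing available accounts for this rise.

Open, going by these compounds, is whether a cyclohexyl ring in place of the phenyl, or a longer chain ending in phenyl, would give a lower number.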